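Swapping Propyl for Propoxy on a Fused-Ring Core

This account rests on a few compounds, and the source may have more. Where it says the series, first, only, none or still open, it means among the compounds named here.

Compound 3 `CCCc1nc(N)c2nc(O)n(Cc3ccccc3)c2n1` gives 1 uM in a functional assay (spleen, spleen) for activation, with Mus musculus as the target; on this read-out higher numbers stand for an effect only at larger amounts of compound and lower numbers for an effect already at smaller amounts. It stands level with compound 1 `Cc1nc(N)c2nc(O)n(Cc3ccccc3)c2n1`, which gives 1 uM; together these two are the highest numbers of the three measured, since no change at the digits printed from compound 1 to compound 3 (within the scatter). Compound 2 `CCCCSc1nc(N)c2nc(O)n(Cc3ccccc3)c2n1` gives 0.01 uM, far lower, because a 100-fold higher number from compound 2 to compound 3 (2.00 log units; beyond the scatter).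

Compound 4 `CCCOc1nc(N)c2nc(O)n(Cc3ccccc3)c2n1` differs from compound 3 in one place: propoxy in place of propyl on an aromatic carbon. For the measured compounds named here, the steps that bear on this are a 100-fold lower number from compound 1 to compound 2 (2.00 log units; beyond the scatter) and a 100-fold higher number from compound 2 to compound 3 (2.00 log units; beyond the scatter), both showing that a chain attached through a heteroatom at this position gives a much lower number than a plain carbon chain. A lower number is therefore expected in this assay, though perhaps not as far as with butylsulfanyl, giving an estimated 33-fold lower number from compound 3 to compound 4 (1.52 log units; beyond the scatter). Compound 4 is expected at 0.03 uM, with a range from 0.005 uM to 0.3 uM.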

Compound 4, minimum effective concentration: 0.01 uM
Estimate against measurement, compound 4: 3.0-fold (0.48 log units) above; the measured number falls inside the stated range.
By their numbers in this assay, from the lowest: compounds 2 and 4 (each within the scatter of the next); then compounds 1 and 3 (each within the scatter of the next).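

In this assay, propoxy keeps the three carbons of propyl and adds a linking oxygen, yet this gives a 100-fold lower number from compound 3 to compound 4 (2.00 log units; beyond the scatter), so at this position the linking atom matters and not the carbon count alone. Propoxy also gives a 100-fold lower number from compound 1 to compound 4 (2.00 log units; beyond the scatter) and no change at the digits printed from compound 2 to compound 4 (within the scatter), which shows that butylsulfanyl, linked through sulfur, is not the only chain that reaches this low level. The data offer no explanation for the effect of the linking atom.

From the compounds shown here alone, it remains open whether a nitrogen link, as in propylamino, would match the oxygen. Going by these compounds, it also remains open whether a longer chain such as hexyloxy would keep the low number.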